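The source may hold more compounds than are shown below. What is called first, only, known or untested is meant among the compounds shown, and "the series" means these compounds.

The measured compounds:
compound 1, `c1ccc([B-]2(c3ccccc3)[NH2+]CCS2)cc1`: 93500 nM
compound 2, `Fc1ccc([B-]2(c3ccccc3)[NH2+]CCO2)cc1`: 33600 nM
compound 3, `Cc1ccc([B-]2(c3ccccc3)[NH2+]CCO2)cc1`: 12900 nM

In an assay on HEK293 cells for inhibition of transient receptor potential cation channel subfamily V member 6 (Homo sapiens), read by FLIPR, with a stated time of 5 min (on this read-out lower numbers stand for stronger inhibition and higher numbers for weaker inhibition), compound 3 gives the lowest number of the three measured compounds. Its nearest neighbour is compound 2, whose value of 33600 nM lies beyond the scatter above it, and the furthest is compound 1, whose value of 93500 nM is higher still. Within the data shown here, the one measured step, a 2.6-fold lower number from compound 2 to compound 3 (0.42 log units; beyond the scatter), exchanges one small aromatic substituent for another on the shared core and moves the number down.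

Compound 4, `CCCCc1ccc([B-]2(c3ccccc3)[NH2+]CCO2)cc1`, differs from compound 3 by propyl in place of hydrogen on a saturated chain carbon bound to an aromatic carbon. Among the measured compounds shown here, no measured step lengthens an alkyl chain, so the only guidance is indirect: the step from compound 2 to compound 3 shows that the substituent on the aromatic ring changes the result in this assay, but it says nothing about how a longer chain would behave. On that basis a small further lowering of the number is expected, though one that might not clear the scatter. Compound 4 is therefore estimated to give 8000 nM in this assay, with a range from 2500 nM to 25000 nM. The expected step of a 1.6-fold lower number from compound 3 to compound 4 (0.21 log units; within the scatter) is modest and uncertain in size.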

Compound 4, half-maximal inhibitory concentration: 12100 nM
The estimate for compound 4 lay 1.5-fold (0.18 log units) below the measured number; measured number inside the range.
By their numbers in this assay, from the lowest: compounds 4 and 3 (each within the scatter of the next); then compound 2; then compound 1.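

In this assay, the step of a 1.1-fold lower number from compound 3 to compound 4 (0.03 log units; within the scatter) shows that replacing hydrogen with propyl on a saturated chain carbon bound to an aromatic carbon, which turns methyl into butyl, leaves the two compounds within the scatter of each other, so this longer chain gives no separable change in the number. The step of a 2.8-fold lower number from compound 2 to compound 4 (0.44 log units; beyond the scatter), read beside the earlier 2.6-fold lower number from compound 2 to compound 3 (0.42 log units; beyond the scatter), shows that the butyl and the methyl compounds both stand beyond the scatter from the fluoro compound, and the difference seen earlier therefore holds for more than one alkyl group. Nothing available bears on why the number stays level across this chain extension.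

The compounds shown leave open how a longer chain such as octyl, or an amine or a carboxylic acid in place of the butyl, would read in this assay. They also leave open what a single change from oxygen to sulfur in the shared core would do, since compound 1, at 93500 nM, differs from each of the others in more than one place.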